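A fluoro to chloro swap at the assay limit

This account rests on a few compounds, and the source may have more. Where it says the series, first, only, none or still open, it means among the compounds named here.

Measured in a functional assay on KYSE-410 cells (Homo sapiens) for antiproliferative activity, read by MTT assay, with a stated time of 72 h; a higher number here means a weaker inhibitor, a lower number a stronger inhibitor:
Compound 1 `O=C(c1ccnc2cc(Br)ccc12)N1CCCCC1`: > 20000 nM, a limit
Compound 2 `O=C(Nc1ccc(F)cc1)c1ccnc2cc(Br)ccc12`: > 20000 nM, a limit

Neither result is a true number, so neither compound can be ranked against the other. The whole picture so far is the limit of > 20000 nM in this assay, at which 2 of the 2 values shown sit. Compound 2 gives > 20000 nM, which marks the limit of this assay and nothing finer.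

The next compound, compound 3 `O=C(Nc1ccc(Cl)cc1)c1ccnc2cc(Br)ccc12`, keeps the shared core and the amide of compound 2. Among the compounds with values here, the only change is chloro in place of fluoro on an aromatic carbon, para to a large group, so 4-fluorophenyl becomes 4-chlorophenyl (chloro in place of fluoro on an aromatic carbon).

Within the data shown here, no measured pair of compounds differs in just one place, so the data offer no step to use as a guide for size. No step beyond the usual scatter is expected in this assay, and no direction can be favoured. The expectation rests on compound 2, with its reading of > 20000 nM. The expected change is a number no higher from compound 2 to compound 3 (the limit leaves the size open). Another limit is the likeliest report, and for compound 3 the estimate is 20000 nM, with an expected range of 8000 nM to 40000 nM.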

Compound 3, half-maximal inhibitory concentration: > 20000 nM
Compound 3 was reported as a limit; the forecaster's own chance of this, stated with the estimate: 70%; the middle value sits exactly at the limit.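

Compound 2 and compound 3 are both reported only as limits, so the change from fluoro to chloro gives no step that can be read, for this reason: the limit of > 20000 nM in this assay, at which 3 of the 3 values shown sit.

The compounds shown leave open whether any of these structures would give a true number in this assay and how fluoro and chloro would then compare.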